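Cyclohexyl for ethyl on an acyl pyrazole amine

The compounds below may be only part of what the source reports. "The series", "measured", "known", "first", "only" and "open" are said of these compounds alone.

Measured compounds:
Compound 1, `Cc1cccc(-c2c(N)n[nH]c2C)c1`, in an assay on Sf9 cells for inhibition of inhibitor of nuclear factor kappa-B kinase subunit epsilon (Homo sapiens), read by ADP-Glo, with a stated time of 60 min (on this read-out higher numbers stand for weaker inhibition and lower numbers for stronger inhibition), gives > 100000 nM, a limit of the assay.
Compound 2, `CCC(=O)n1nc(C)c(-c2ccc(Cl)c(Cl)c2)c1N`, in this assay gives > 100000 nM, also a limit of the assay.

Both values sit at the limit of > 100000 nM in this assay, at which 2 of the 2 values shown sit, so neither compound shows measurable inhibition, and compound 2 stands only at a limit, with no number of its own. Nothing in the two values sets the compounds apart from each other.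

Compound 3, `Cc1nn(C(=O)C2CCCCC2)c(N)c1-c1ccc(Cl)c(Cl)c1`, carries a single change relative to compound 2: cyclohexyl in place of ethyl on a carbonyl carbon. The amine on the core and the dichlorophenyl group are kept unchanged.

Among the compounds with values here, no measured step exists between two numbered values here, so no step size can be read from the data. With compound 2 at a limit, the working expectation for compound 3 is that the change from ethyl to cyclohexyl leaves the read-out at or near that limit, with no shift beyond the scatter in this assay.

The expected step from compound 2 to compound 3 is a number no higher from compound 2 to compound 3 (the limit leaves the size open). Compound 3 is therefore estimated at 100000 nM, within a range from 30000 nM to 300000 nM.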

Compound 3, half-maximal inhibitory concentration: > 100000 nM
Compound 3 gave a limit, no number (the forecaster's own chance of this, stated with the estimate: 70%); the middle value lies on the limit itself.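

No step can be read from compound 2 to compound 3, because both results are limits of the assay and not numbers: the limit of > 100000 nM in this assay, at which 3 of the 3 values shown sit.

The compounds shown leave open whether cyclohexyl in place of ethyl on a carbonyl carbon alters inhibition at all, and which compounds of this kind would give a measurable number in this assay.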